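Cyclopentyl in place of allyl on the shared core

The compounds below may be only part of what the source reports. "The series", "measured", "known", "first", "only" and "open" are said of these compounds alone.

Measured in a functional assay on MCF7 cells (Homo sapiens) for cytotoxicity, read by MTT assay, with a stated time of 48 h; a higher number here means a weaker inhibitor of growth, a lower number a stronger inhibitor of growth:
Compound 1 `C=CCn1c(C(F)(F)F)nc2cc(Cl)c(Cl)cc21`: 87000 nM
Compound 2 `O=[N+]([O-])c1ccc(Cn2c(C(F)(F)F)nc3cc(Cl)c(Cl)cc32)cc1`: 97300 nM

In this assay, compound 1 at 87000 nM lies within the scatter of compound 2 at 97300 nM, so neither stands apart from the other. Compound 3 `FC(F)(F)c1nc2cc(Cl)c(Cl)cc2n1C1CCCC1` has not yet been measured. It carries cyclopentyl in place of allyl on an aromatic nitrogen. Among the compounds with values here, no measured pair shows what such a swap does, so no step beyond the scatter is expected in this assay, and no direction can be called. The estimated change is a 1.2-fold lower number from compound 1 to compound 3 (0.06 log units; within the scatter). Compound 3 is expected at 75000 nM, within an estimated range of 30000 nM to 180000 nM.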

Compound 3, concentration for 50% growth inhibition: 21000 nM
Estimate against measurement, compound 3: 3.6-fold (0.55 log units) above; measured number below the stated range.
By their numbers in this assay, from the lowest: compound 3; then compounds 1 and 2 (each within the scatter of the next).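

Within the data shown here, the group on this aromatic nitrogen matters in this assay: cyclopentyl in place of allyl gives a 4.1-fold lower number from compound 1 to compound 3 (0.62 log units; beyond the scatter), a modest step but one beyond the scatter, and the earlier compounds offered no such step to read. Nothing measured here accounts for this step. The compounds shown leave open whether the ring itself or simply the added carbon goes with the lower number. They also leave open how a cyclohexyl ring, a saturated propyl chain or a chain bearing an amine would read at this nitrogen.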